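This account rests on a few compounds, and the source may have more. Where it says the series, first, only, none or still open, it means among the compounds named here.

Compound 1 `COc1ccc(CN2C(=O)/C(=C\c3cc(OC)c(OC)c(OC)c3)c3ccccc32)cc1` gives 2300 nM in a functional assay on cells (Cancer cell lines, Homo sapiens) for cytotoxicity, with a stated time of 48 h; on this read-out higher numbers stand for weaker inhibition of growth and lower numbers for stronger inhibition of growth. Compound 2 `COc1cc(/C=C2\C(=O)N(C)c3ccc(Cl)cc32)cc(OC)c1OC` gives 3700 nM in this assay. Compound 1 has the lower of the two numbers, but its gap to compound 2 sits within the scatter, so no order between them can be read. Compound 3 `COc1cc(/C=C2\C(=O)N(Cc3ccc(Cl)cc3)c3ccccc32)cc(OC)c1OC` is not yet measured and differs from compound 1 in one place: chloro in place of methoxy on an aromatic carbon. Going by the values given here, no measured pair carries this change, so in this assay a step of no more than the scatter is expected, in either direction. Compound 3 is expected to give about 2500 nM in this assay, between 1000 nM and 6500 nM, an expected step of a 1.1-fold higher number from compound 1 to compound 3 (0.04 log units; within the scatter) that stays within the scatter.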

Compound 3, concentration for 50% growth inhibition: 2400 nM
The estimate for compound 3 lay 1.0-fold (0.02 log units) above the measured number, within the range that was stated.
By their numbers in this assay, from the lowest: compounds 1, 3 and 2 (each within the scatter of the next).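

Chloro in place of methoxy on the aromatic carbon para to a large group gives the only matched step in the series: in this assay it reads a 1.0-fold higher number from compound 1 to compound 3 (0.02 log units; within the scatter). On this read-out, 4-methoxybenzyl and 4-chlorobenzyl therefore cannot be told apart. No measurement shown here bears on this result. Still open, from the compounds shown here alone, is whether an amine or a carboxylic acid on this same aromatic carbon would give a step beyond the scatter. Also open, going by these compounds, is how a longer chain in place of methoxy would read.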